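The source may hold more compounds than are shown below. What is called first, only, known or untested is meant among the compounds shown, and "the series" means these compounds.

Of the compounds shown here, three have so far been measured in an assay on isolated protein for displacement of a labelled ligand from metabotropic glutamate receptor 5 (Homo sapiens), with a stated time of 60 min, tested at 1 uM; a higher number here means more inhibition at the concentration tested (going by the name of the read-out), a lower number less inhibition. Compound 1 `Cc1ccc(S(=O)(=O)c2cnc3c(F)cccc3c2N2CCC(C)CC2)cc1` gives 93%, and compound 2 `Cc1ccc(S(=O)(=O)c2cnc3c(F)cccc3c2N2CCC(C)CC2)cc1F` gives 93%. These two differ in a single place: hydrogen in place of fluoro on an aromatic carbon. The resulting step, no change at the digits printed from compound 2 to compound 1 (within the scatter), lies within the scatter of this kind of measurement. Compound 3 `NS(=O)(=O)N1CCN(c2c(S(=O)(=O)c3cc(F)cc(F)c3)cnc3cc(F)ccc23)CC1` gives 6.4%, the lowest of the three numbers; its nearest neighbour is compound 1, whose number stands higher by a gap beyond the scatter, and compound 2 stands higher by the same gap. How the core of compound 3 differs from the core of compound 2 is not broken down here.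

Compound 4 `NS(=O)(=O)N1CCN(c2c(S(=O)(=O)c3cccc(F)c3)cnc3cc(F)ccc23)CC1` has not yet been measured. It differs from compound 3 by the same kind of change that was made from compound 2 to compound 1: hydrogen in place of fluoro on an aromatic carbon. The surroundings of that place are not identical, though: in compound 2 the fluoro that leaves sits ortho to a methyl group and meta to a large group, whereas in compound 3 it sits meta to a fluoro group and meta to a large group. The measured example of this kind of change gave no change within the scatter. On that basis the step of a number 1.6 percentage points higher from compound 3 to compound 4 (within the scatter) is expected to be small, because no change at the digits printed from compound 2 to compound 1 (within the scatter) showed no movement for the same kind of change. Compound 4 is accordingly estimated at 8%, with a range from 0% to 25% in this assay.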

Compound 4, a percentage reported as inhibition, at one concentration (the size of the read-out at that concentration, not a potency): 1.9%
Compound 4: middle estimate off by 6.1 percentage points, on the high side; the range from low to high includes it.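

Replacing a fluoro on an aromatic carbon with hydrogen has now been seen on two cores in this assay, and the new case, 3,5-difluorophenyl to 3-fluorophenyl, gives a number 4.5 percentage points lower from compound 3 to compound 4 (within the scatter). Set side by side, the two cases do not differ, so in these two examples the change carries from one core to the other without a visible difference: the same change on two cores in this assay, no change at the digits printed (within the scatter) from compound 2 to compound 1 and a number 4.5 percentage points lower (within the scatter) from compound 3 to compound 4, 4.5 percentage points apart, within the scatter of two such steps This does not show that the swap is without effect on every core in the series, since each pair of compounds lies close to one end of the percentage scale, where a reading at a single concentration has little room to show movement, and such a reading is not a potency.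

The compounds shown leave open how the same swap behaves on a core whose number falls in the middle of the scale, where a shift would be easier to see. They also leave open what a group other than hydrogen or fluoro, such as a chlorine, a methoxy group or a nitrile, would do at this place on the ring.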